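A few compounds are considered here, and "the series" means these few. Any claim that something is new, unique, unknown or untested is made for them only; others in the source may bear on it.

Compound 3, `COC(=O)c1c(Nc2ccccc2)sc(C(=O)c2ccc(C)cc2)c1C`, stands lowest of the two compounds that have a number in a functional assay, with a stated time of 150 min, tested at 35 ug/mL; a higher number here means a stronger effect of the compound at the concentration tested, a lower number a weaker effect: compound 3 gives 10.3%, whereas compound 1, `COC(=O)c1c(Nc2ccccc2)sc(C(=O)c2ccc(OC)cc2)c1C`, gives 63%. Among the compounds with values here, the only step between measured compounds that differ in one place is a number 52.7 percentage points lower from compound 1 to compound 3 (beyond the scatter). Within the data shown here, a third compound, compound 2, `COC(=O)c1c(Nc2ccc(C)cc2)sc(C(=O)c2ccc(OC)cc2)c1C`, carries a methyl on the anilino ring, on an aromatic carbon para to a large group, and in this assay compound 2 is reported as "not active" (no number reported), with no number given, so no step can be computed for it.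

The next compound, compound 4, `COC(=O)c1c(Nc2ccc(C)cc2)sc(C(=O)c2ccc(C)cc2)c1C`, differs from compound 3 by methyl in place of hydrogen on an aromatic carbon. Among the measured compounds shown here, no measured step covers this change directly. What the values of compound 1 and compound 2 show is that compound 1 gives a clear number while compound 2, which carries the same methyl, is reported as not active. Compound 3 starts low already, so in this assay the step of a number 7.3 percentage points lower from compound 3 to compound 4 (within the scatter) is expected to be small and downward, probably within the scatter. Compound 4 is therefore estimated to give 3%, with a likely range from 0% to 15%, and a fair chance that it is again reported only as not active.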

Compound 4, a percentage reported as activity, at one concentration (the size of the read-out at that concentration, not a potency): "not active" (no number reported)
Nothing numeric was reported for compound 4, so the estimate cannot be set against anything.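

In this assay, within the data shown here, compound 3 gives 10.3% while compound 4 is reported as not active with no number, so no step between compound 3 and compound 4 can be read. Nothing shown here explains this result. The compounds shown leave open how large an effect the change from phenyl to 4-methylphenyl has on the read-out.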